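From a Fluorinated Indazole to a Chlorinated One

A few compounds are considered here, and "the series" means these few. Any claim that something is new, unique, unknown or untested is made for them only; others in the source may bear on it.

Of the compounds shown here, two built on one shared core have so far been measured in a functional assay on MCF7 cells (Homo sapiens) for cytotoxicity, read by CellTiter-Glo, with a stated time of 5 days; on this read-out lower numbers stand for stronger inhibition and higher numbers for weaker inhibition. Compound 1 `CC/C(=C(/c1ccc(/C=C/C(=O)O)cc1)c1ccc2[nH]ncc2c1C)c1ccccc1` gives 50 nM in this assay, and compound 2 `CC/C(=C(/c1ccc(/C=C/C(=O)O)cc1)c1ccc2[nH]nc(F)c2c1)c1ccccc1` gives 5 nM in this assay. Among the measured compounds shown here, the one structural change between them, replacing the 4-methyl-1H-indazol-5-yl group with a 3-fluoro-1H-indazol-5-yl group, produced a 10-fold lower number from compound 1 to compound 2 (1.00 log units; beyond the scatter). For the measured compounds named here, compound 2 therefore stands at the lowest of the two numbers known.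

Compound 3 `CC/C(=C(/c1ccc(/C=C/C(=O)O)cc1)c1ccc2[nH]ncc2c1Cl)c1ccccc1` has not yet been measured. It differs from compound 2 by 4-chloro-1H-indazol-5-yl in place of 3-fluoro-1H-indazol-5-yl on a double-bonded chain carbon bound to an aromatic carbon and a double-bonded chain carbon. Going by the values given here, only one measured step bears on this change: the step from compound 1 to compound 2, in which the group that sat at the 4-position of the indazole in compound 1 went with the higher number, and this step was beyond the scatter. Compound 3 again carries a group at that same position of the indazole, a chlorine in place of the methyl of compound 1, so the number is expected to rise, by about a 6.0-fold higher number from compound 2 to compound 3 (0.78 log units; beyond the scatter). Compound 3 is thus estimated at about 30 nM, with a likely range from 8 nM to 120 nM.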

Compound 3, half-maximal inhibitory concentration: 1.6 nM
For compound 3 the middle estimate is 19-fold (1.27 log units) above the measured one; the whole stated range lies above it.
By their numbers in this assay, from the lowest: compound 3; then compound 2; then compound 1.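

The earlier pair could be read as saying that a group on this carbon of the indazole goes with a higher number, but this result rules that reading out: putting chloro in place of methyl on the same aromatic carbon gives a 31-fold lower number from compound 1 to compound 3 (1.49 log units; beyond the scatter) and leaves a group there all the same. So the identity of the group matters, not merely the presence of one, and 4-chloro-1H-indazol-5-yl also outdoes 3-fluoro-1H-indazol-5-yl, with a 3.1-fold lower number from compound 2 to compound 3 (0.49 log units; beyond the scatter) and with both steps beyond the usual scatter, which puts compound 3 lowest of the three. No independent measurement is available to explain why these groups separate so clearly.

With only methyl and chloro shown on this aromatic carbon, it remains open whether a bromo, methoxy or nitrile group there would go with a lower or a higher number than chloro. Also open, going by these compounds, is whether chloro and the fluoro of compound 2, carried together on one indazole, would lower the number further or work against each other.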